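The source may hold more compounds than are shown below. What is called first, only, known or untested is meant among the compounds shown, and "the series" means these compounds.

Working notes on the hydrazide sulfonamide series. In an assay for inhibition of Indoleamine 2,3-dioxygenase 1 (Homo sapiens), read by spectrophotometry, with stated times of 1 h and 4 h (a higher number here means a weaker inhibitor, a lower number a stronger inhibitor), compound 1 `COc1ccc(NNS(=O)(=O)c2ccc(NC(C)=O)cc2)cc1` gives 254 nM and compound 2 `CC(=O)Nc1ccc(S(=O)(=O)NNc2ccc(C(F)(F)F)cc2)cc1` gives 1610 nM. Among the measured compounds shown here, the single measured step, a 6.3-fold higher number from compound 1 to compound 2 (0.80 log units; beyond the scatter), is the only comparison so far, so compound 2 stands as the higher of the two numbers, with compound 1 as its nearest neighbour.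

Compound 3 `CC(=O)Nc1ccc(S(=O)(=O)NNc2ccc(F)cc2)cc1` is not yet measured in this assay . It differs from compound 2 by fluoro in place of trifluoromethyl on an aromatic carbon. For the measured compounds named here, no measured step touches fluoro at that position; the only step that bears on the change is a 6.3-fold higher number from compound 1 to compound 2 (0.80 log units; beyond the scatter), which shows that the trifluoromethyl analogue sits well above the methoxy analogue. Because compound 2 reads 1610 nM and compound 1 reads 254 nM, the expectation is that compound 3 falls between them, and the estimated step is a 2.7-fold lower number from compound 2 to compound 3 (0.43 log units; beyond the scatter) toward a lower number. Compound 3 is therefore expected to give about 600 nM in this assay , with a range from 200 nM to 1800 nM; the direction is the more secure part of the estimate, the size is not.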

Compound 3, half-maximal inhibitory concentration: 79 nM
Compound 3: middle estimate off by 7.6-fold (0.88 log units), on the high side; measured number below the stated range.
By their numbers in this assay, from the lowest: compound 3; then compound 1; then compound 2.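

At this position, on an aromatic carbon para to a large group, the span of readings in this assay is wider than the first pair showed, and the single atom of fluoro gives the largest change so far: a 20-fold lower number from compound 2 to compound 3 (1.31 log units; beyond the scatter). Methoxy no longer marks the low end of the series, since fluoro also reads lower than methoxy, with a 3.2-fold lower number from compound 1 to compound 3 (0.51 log units; beyond the scatter), so compound 3 is now the strongest inhibitor of the three, with its steps to both others beyond the scatter. No measurement on hand speaks to what lies behind this ordering.

Three groups at one position cannot show whether the low reading is particular to fluoro or is shared by other halogens such as chloro or bromo, and they give no indication of what a nitrile, an amine or a carboxylic acid would read at the same place. Going by these compounds, the acetamide group is common to compound 1, compound 2 and compound 3, so its contribution to these readings also remains open.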